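The source may report more compounds than this note shows. Statements on the series, on what has been measured and on what is new or still open speak of the compounds shown alone.

Measured so far:
compound 1, `Fc1cccc(-c2cn([C@@H]3CN4CCC3CC4)nn2)c1`: 519 nM
compound 2, `c1ccc(COc2cccc(-c3cn([C@@H]4CN5CCC4CC5)nn3)c2)cc1`: 414 nM
compound 3, `Fc1ccc(COc2cccc(-c3cn([C@@H]4CN5CCC4CC5)nn3)c2)cc1`: 537 nM

In an assay on HEK293 cells for displacement of a labelled ligand from Neuronal acetylcholine receptor; alpha4/beta2 (Homo sapiens), read by scintillation counting, with a stated time of 120 min (on this read-out higher numbers stand for weaker inhibition and lower numbers for stronger inhibition), compound 1 gives 519 nM, the second highest of the three numbers. Its nearest neighbour is compound 3, which gives 537 nM, a step of a 1.0-fold higher number from compound 1 to compound 3 (0.01 log units; within the scatter). The furthest is compound 2, which gives 414 nM, a step of a 1.3-fold lower number from compound 1 to compound 2 (0.10 log units; within the scatter). Between the two benzyloxy compounds the step is a 1.3-fold higher number from compound 2 to compound 3 (0.11 log units; within the scatter). Going by the values given here, all three numbers sit within the scatter of one another, so the series so far shows no separation among them.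

Compound 4 `Fc1cccc(-c2cn([C@H]3CN4CCC3CC4)nn2)c1` keeps every atom and bond of compound 1 and differs only in configuration: the two compounds have the same atoms and bonds; at least one stereo element is drawn with a configuration in one of them and without one in the other: 1 of 3 stereo elements differ; a stereocentre at a saturated ring carbon is drawn S in compound 1 and R in compound 4. Among the compounds with values here, none of the measured steps touches this stereocentre; each of them exchanges a group on the aromatic ring while the saturated ring carbon is kept as drawn in compound 1. The measured steps therefore give no guidance on the size or direction of the change to expect, and the expectation rests on compound 1 alone, with a wide spread. Compound 4 is expected at 1200 nM, with a range of 300 nM to 6000 nM. The step this estimate implies is expected to be a 2.3-fold higher number from compound 1 to compound 4 (0.36 log units; beyond the scatter).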

Compound 4, inhibition constant: 5200 nM
Estimate against measurement, compound 4: 4.3-fold (0.64 log units) below, within the range that was stated.
By their numbers in this assay, from the lowest: compounds 2, 1 and 3 (each within the scatter of the next); then compound 4.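

In this assay, going by these compounds alone, the stereocentre at the saturated ring carbon, drawn R in place of S with all atoms and bonds kept, gives a 10-fold higher number from compound 1 to compound 4 (1.00 log units; beyond the scatter), the first step beyond the scatter. The aromatic exchanges among compounds 1, 2 and 3 all stayed within the scatter, so among these compounds only the configuration at this carbon separates one number from the rest, with the S drawing on the side of stronger inhibition. The reading of this step carries one caution: the fact that one of compounds 1 and 4 is drawn with a defined configuration and the other without, at the place where they differ

The compounds shown do not tell whether the R drawing has a step of similar size with benzyloxy or (4-fluorobenzyl)oxy on the aromatic ring. Also open, from the compounds shown here alone, is whether an amine or a carboxylic acid in place of fluoro would separate from compound 1 at all.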